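Lengthening the Chain from Compound 3 to Compound 4

The source may report more compounds than this note shows. Statements on the series, on what has been measured and on what is new or still open speak of the compounds shown alone.

Measured in a functional assay on HEL cells (Homo sapiens) for cytotoxicity; a higher number here means that more compound is tolerated, a lower number that less compound is tolerated:
- Compound 1 `CCCCCc1cc2cn([C@H]3C[C@H](O)[C@@H](CO)O3)c(=O)nc2o1` gives > 50000 nM, a limit.
- Compound 2 `CCCCCCCc1cc2cn([C@H]3C[C@H](O)[C@@H](CO)O3)c(=O)nc2o1` gives > 50000 nM, a limit.
- Compound 3 `CCCCCCCCc1cc2cn([C@H]3C[C@H](O)[C@@H](CO)O3)c(=O)nc2o1` gives > 50000 nM, a limit.

In this assay compound 3 gives > 50000 nM, which is a limit and not a number. It shares this position with the other two compounds, as the limit of > 50000 nM in this assay, at which 3 of the 3 values shown sit, shows. Compound 4 `CCCCCCCCCCc1cc2cn([C@H]3C[C@H](O)[C@@H](CO)O3)c(=O)nc2o1` differs from compound 3 by one change, (ethyl in place of hydrogen on a saturated chain carbon, eight bonds along the chain from an aromatic carbon). Among the measured compounds shown here, three measured steps bear on this change: a step that the two limits leave unreadable from compound 1 to compound 2, a step that the two limits leave unreadable from compound 1 to compound 3 and a step that the two limits leave unreadable from compound 2 to compound 3. None of them has a readable size, so none supplies a size or a direction to carry forward. No step beyond the usual scatter is therefore expected, and another result reported only as a limit is the likeliest outcome. The expected step is a number no higher from compound 3 to compound 4 (the limit leaves the size open). The estimated value for compound 4 is 50000 nM, with an expected range from 20000 nM to 100000 nM.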

Compound 4, half-maximal cytotoxic concentration: > 50000 nM
Compound 4: no number, only a limit; the forecaster's own chance of this, stated with the estimate: 75%; the middle value sits exactly at the limit.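

In this assay compound 4 gives > 50000 nM as a limit and not a number. Among the compounds shown here, no step from compound 1, compound 2 or compound 3 to compound 4 can be read, as all four compounds share one position: the limit of > 50000 nM in this assay, at which 4 of the 4 values shown sit.

The compounds shown leave open whether chain length has any effect on the tolerated concentration.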